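Substituent on the ring amide nitrogen: benzyl, hydrogen, methyl

The compounds below may be only part of what the source reports. "The series", "measured", "known", "first", "only" and "open" are said of these compounds alone.

Measured so far:
compound 1 `CC(C)(C)OC(=O)/C=C1/C(=O)Nc2ccccc21` — 87.3%
compound 2 `CC(C)(C)OC(=O)/C=C1/C(=O)N(Cc2ccccc2)c2ccccc21` — 88%

Both compounds share the same core and differ only at the amide-type nitrogen in the ring. In a functional assay on SK-BR-3 cells (Homo sapiens) for inhibition, read by CCK-8 assay, with a stated time of 72 h, tested at 20 uM (on this read-out lower numbers stand for less inhibition of growth and higher numbers for more inhibition of growth at the one concentration tested), compound 1 gives 87.3% and compound 2 gives 88%; the two numbers lie within the scatter of each other, and the step of a number 0.7 percentage points higher from compound 1 to compound 2 (within the scatter) therefore shows no real change. Compound 2 thus stands level with compound 1 on the numbers at hand, at the upper edge of this narrow pair.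

Compound 3 `CN1C(=O)/C(=C/C(=O)OC(C)(C)C)c2ccccc21` is not yet measured. It differs from compound 2 by hydrogen in place of phenyl on a saturated chain carbon bound to an amide-type nitrogen in a ring; the same difference, cut one bond further out, reads benzyl to methyl. Among the compounds with values here, the only step that bears on this position is the one from compound 1 to compound 2, where hydrogen became benzyl with the result a number 0.7 percentage points higher from compound 1 to compound 2 (within the scatter), within the scatter. Trimming the benzyl back to methyl is expected to sit in the same quiet region, with a number 1 percentage points lower from compound 2 to compound 3 (within the scatter) as the expected step and no direction beyond the scatter. Compound 3 is estimated at 87%, within 76% to 95%.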

Compound 3, percent growth inhibition at one concentration: 87.6%
The estimate for compound 3 lay 0.6 percentage points below the measured number, and the stated range covers the measured number.
By their numbers in this assay, from the lowest: compounds 1, 3 and 2 (each within the scatter of the next).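

In this assay, trimming the benzyl back gives a number 0.4 percentage points lower from compound 2 to compound 3 (within the scatter) and putting methyl on the amide-type nitrogen in the ring gives a number 0.3 percentage points higher from compound 1 to compound 3 (within the scatter), so methyl now reads level with both hydrogen and benzyl. The earlier pair offered only the two end points of this series, and compound 3 adds a third substituent on the same nitrogen, showing that removal of the phenyl from the saturated chain carbon also produces no readable change. All three steps among compound 1, compound 2 and compound 3 now lie within the scatter, so the position appears tolerant across these three substituents only, and nothing available explains that flat reading.

Because every reading comes from one concentration, the notes cannot say whether these three compounds would stay level at lower concentrations, where a separation might or might not appear. Also open, as far as these compounds go, is whether a longer chain, or a chain ending in an amine or a carboxylic acid, on the ring amide nitrogen would keep the number in the same region, and whether any change away from this nitrogen, such as replacing the tert-butyl ester, would move it.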